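Replacing fluoro with thiophen-3-yl on a weak lipoxygenase inhibitor

The compounds below may be only part of what the source reports. "The series", "measured", "known", "first", "only" and "open" are said of these compounds alone.

Measured compounds:
compound 1 `O=C1NCCN(c2cccc(F)c2)N1` with 19000 nM
compound 2 `CC1CN(c2cccc(F)c2)NC(=O)N1` with 6300 nM
compound 3 `O=C1NCCN(c2ccnc3cc(Cl)ccc23)N1` with 32000 nM

In an assay on RBL-1 cells for inhibition of Polyunsaturated fatty acid 5-lipoxygenase (Rattus norvegicus) (a lower number here means a stronger inhibitor, a higher number a weaker inhibitor), compound 1 gives 19000 nM. Compound 3 gives 32000 nM in this assay, and the two values lie within the scatter of each other, so nothing separates them. Compound 2, in which a methyl replaces a hydrogen on a saturated ring carbon of the shared core, gives 6300 nM; the step of a 3.0-fold lower number from compound 1 to compound 2 (0.48 log units; beyond the scatter) is the only one beyond the scatter among the three.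

Compound 4 `O=C1NCCN(c2cccc(-c3ccsc3)c2)N1` differs from compound 1 in one place: thiophen-3-yl in place of fluoro on an aromatic carbon. Among the measured compounds shown here, none of the measured steps touches this part of the molecule. For the measured compounds named here, the step from compound 1 to compound 2 concerns the saturated ring, and the pair of compound 1 and compound 3 shows only that a change of the aromatic group bound to the core can leave the number within the scatter. The data therefore give no direct guide to the size or direction of the step to compound 4, and a wide range is appropriate.

Compound 4 is expected to give 9000 nM in this assay, a step of a 2.1-fold lower number from compound 1 to compound 4 (0.32 log units; beyond the scatter), with a range from 2000 nM to 40000 nM.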

Compound 4, half-maximal inhibitory concentration: 4900 nM
For compound 4 the middle estimate is 1.8-fold (0.26 log units) above the measured one; the measured number falls inside the stated range.
By their numbers in this assay, from the lowest: compounds 4 and 2 (each within the scatter of the next); then compounds 1 and 3 (each within the scatter of the next).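

In this assay, the aromatic carbon that carries fluoro in compound 1 accepts a far larger group: thiophen-3-yl, with 5 heavy atoms in place of 1, gives a 3.9-fold lower number from compound 1 to compound 4 (0.59 log units; beyond the scatter) and so lies beyond the scatter. This is the first step shown at this position, and it establishes that a change on the aromatic ring, and not only the methyl on the saturated ring carbon in a 3.0-fold lower number from compound 1 to compound 2 (0.48 log units; beyond the scatter), can move the number measurably. Nothing in the data explains why the thiophen-3-yl group lowers the number.

The compounds shown leave open whether the sulfur matters, since a phenyl or furan-3-yl group on the same aromatic carbon would separate the ring itself from its hetero atom, while thiophen-2-yl would test how the ring is attached. They also leave open whether the methyl on the saturated ring carbon of compound 2 and the thiophen-3-yl group of compound 4 would add up in a single molecule.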